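Amine size on a side chain: one change at two chain lengths

The source may hold more compounds than are shown below. What is called first, only, known or untested is meant among the compounds shown, and "the series" means these compounds.

Compound 1 `CN(C)CCn1c(N)c(-c2nc3ccccc3[nH]2)c2nc(C#N)c(C#N)nc21`: 43500 nM
Compound 2 `CCN(CC)CCn1c(N)c(-c2nc3ccccc3[nH]2)c2nc(C#N)c(C#N)nc21`: 25400 nM
Compound 3 `CN(C)CCCCn1c(-c2c(N)n(C)c3nc(C#N)c(C#N)nc23)nc2ccccc21`: 6480 nM

In a functional assay on cells (Homo sapiens) for antiproliferative activity, read by MTT assay, with a stated time of 48 h (a lower number here means a stronger inhibitor, a higher number a weaker inhibitor), compound 1 gives 43500 nM and compound 2 gives 25400 nM. The two differ only by diethylamino in place of dimethylamino on a saturated chain carbon, two bonds along the chain from an aromatic nitrogen, and that change gave a 1.7-fold lower number from compound 1 to compound 2 (0.23 log units; within the scatter). Compound 3 has a different core; the difference between the two cores is not broken down here. Of the three values, the number for compound 3 is the lowest.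

Compound 4 `CCN(CC)CCCCn1c(-c2c(N)n(C)c3nc(C#N)c(C#N)nc23)nc2ccccc21` is not yet measured. It differs from compound 3 by diethylamino in place of dimethylamino on a saturated chain carbon, four bonds along the chain from an aromatic nitrogen, the same kind of change as between compound 1 and compound 2, but here four bonds along the chain from the aromatic nitrogen rather than two. Because a 1.7-fold lower number from compound 1 to compound 2 (0.23 log units; within the scatter) stayed within the scatter, only a small step, a 1.4-fold lower number from compound 3 to compound 4 (0.16 log units; within the scatter), is expected here. Compound 4 is therefore estimated at 4500 nM in this assay.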

Compound 4, half-maximal inhibitory concentration: 6950 nM
For compound 4 the middle estimate is 1.5-fold (0.19 log units) below the measured one; low and high end bracket the measured number.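

In this assay, putting diethylamino in place of dimethylamino four bonds along the chain gave a 1.1-fold higher number from compound 3 to compound 4 (0.03 log units; within the scatter). Set beside the same change on the other core, the two steps agree as far as the scatter allows: the same change on two cores in this assay, a 1.7-fold lower number (0.23 log units; within the scatter) from compound 1 to compound 2 and a 1.1-fold higher number (0.03 log units; within the scatter) from compound 3 to compound 4, 1.8-fold (0.26 log units) apart, within the scatter of two such steps. This suggests the change carries over between these two cores without a measurable shift, but with one small step on each core and a different chain length in each pair, it does not show that amine size is irrelevant or that a third core would respond alike.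

The compounds shown leave open what a larger amine, such as dipropylamino, would do at the chain end. They also leave open how a longer chain would behave on either core.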